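Ethyl in place of methoxy on the carbamate aryl ring

This account rests on a few compounds, and the source may have more. Where it says the series, first, only, none or still open, it means among the compounds named here.

Compound 1 `COc1ccc(S(=O)(=O)N(Nc2ccccc2)C(=O)Oc2ccccc2)cc1` gives 4430 nM in a functional assay on RAW264.7 cells (Mus musculus), read by immunoassay, with a stated time of 24 h (a higher number here means a weaker inhibitor, a lower number a stronger inhibitor), and compound 2 `COc1ccc(OC(=O)N(Nc2ccccc2)S(=O)(=O)c2ccc(OC)cc2)cc1` gives 490 nM in this assay, the lowest of the two numbers. That single step, a 9.0-fold lower number from compound 1 to compound 2 (0.96 log units; beyond the scatter), is the only one known here. Compound 3 `CCc1ccc(OC(=O)N(Nc2ccccc2)S(=O)(=O)c2ccc(OC)cc2)cc1` differs from compound 2 by ethyl in place of methoxy on an aromatic carbon. Nothing measured speaks directly to swapping these two groups of like size; the one step shown concerns adding methoxy, not replacing it. Compound 3 is therefore expected to give 750 nM, within 250 nM to 2500 nM. The estimated step of a 1.5-fold higher number from compound 2 to compound 3 (0.18 log units; within the scatter) is expected to stay near the scatter.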

Compound 3, half-maximal inhibitory concentration: 28.5 nM
The estimate for compound 3 lay 26-fold (1.42 log units) above the measured number, outside the stated range (below it).
By their numbers in this assay, from the lowest: compound 3; then compound 2; then compound 1.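

Compound 1 and compound 2 showed only that methoxy at this aromatic carbon gives a lower number than hydrogen, but ethyl in place of methoxy goes much further, with a 17-fold lower number from compound 2 to compound 3 (1.24 log units; beyond the scatter) beyond that. Two groups of equal heavy-atom count are therefore far from interchangeable here. Measured against hydrogen, ethyl gives a 160-fold lower number from compound 1 to compound 3 (2.19 log units; beyond the scatter) and so the largest step seen at this position, though nothing shown accounts for the gap between ethyl and methoxy.
On these data alone, whether a longer chain such as propyl, or an amine, would extend or reverse this gain at the same carbon stays open. So does whether ethyl acts alike when the rest of the shared core changes.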